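The source may hold more compounds than are shown below. What is called first, only, known or untested is meant among the compounds shown, and "the series" means these compounds.

Measured so far:
Compound 1, `O=C(Nc1cncc2ccccc12)N1CCN(Cc2cccc(Oc3ccc(Cl)cc3)c2)CC1` — in an assay on isolated protein for inhibition of Fatty-acid amide hydrolase 1 (Homo sapiens), with a stated time of 60 min (a higher number here means a weaker inhibitor, a lower number a stronger inhibitor), compound 1 gives 6.7 nM.
Compound 2, `O=C(Nc1noc2ccncc12)N1CCN(Cc2cccc(Oc3ccc(Cl)cc3)c2)CC1` — in this assay compound 2 gives 180 nM.
Compound 3, `O=C(Nc1ccn2ccnc2c1)N1CCN(Cc2cccc(Oc3ccc(Cl)cc3)c2)CC1` — in this assay compound 3 gives 33 nM.

Compound 3 sits in the middle of these three numbers: it is weaker than compound 1, shown by a 4.9-fold higher number from compound 1 to compound 3 (0.69 log units; beyond the scatter), and stronger than compound 2, shown by a 5.5-fold lower number from compound 2 to compound 3 (0.74 log units; beyond the scatter). All three share the same core; only the group on the amide-type nitrogen changes.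

Compound 4, `O=C(Nc1cccc2nccn12)N1CCN(Cc2cccc(Oc3ccc(Cl)cc3)c2)CC1`, is built from the same atoms as compound 3, joined differently: a group of 9 heavy atoms (7 carbon, 2 nitrogen; one five-membered aromatic ring with 2 hetero atoms, one six-membered aromatic ring with 1 hetero atom) in place of a group of 9 heavy atoms (7 carbon, 2 nitrogen; one five-membered aromatic ring with 2 hetero atoms, one six-membered aromatic ring with 1 hetero atom), on an amide-type nitrogen. For the measured compounds named here, no measured step rearranges a group without changing its atoms, so the nearest guides are the swaps of one bicyclic group for another, a 4.9-fold higher number from compound 1 to compound 3 (0.69 log units; beyond the scatter) and a 5.5-fold lower number from compound 2 to compound 3 (0.74 log units; beyond the scatter), both modest. A step of similar modest size in this assay seems likely, and with no direction indicated by the data, a slight weakening is assumed as the middle case, with a wide range.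

Compound 4 is therefore expected to give about 50 nM in this assay, between 10 nM and 250 nM, an estimated step of a 1.5-fold higher number from compound 3 to compound 4 (0.18 log units; within the scatter).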

Compound 4, half-maximal inhibitory concentration: 2.7 nM
Compound 4: the middle estimate sits 19-fold (1.27 log units) above what was measured, outside the stated range (below it).
By their numbers in this assay, from the lowest: compound 4; then compound 1; then compound 3; then compound 2.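

Rearranging the same atoms within the group on the amide-type nitrogen, with the counts of hydrogen-bond donors and acceptors unchanged, gives a 12-fold lower number from compound 3 to compound 4 (1.09 log units; beyond the scatter) in this assay, so at this position how the atoms are joined matters as well as which atoms are present. Compound 4 is the strongest of the four, with a 2.5-fold lower number from compound 1 to compound 4 (0.39 log units; beyond the scatter) and a 67-fold lower number from compound 2 to compound 4 (1.82 log units; beyond the scatter), yet compounds 2 and 3 also carry groups of 9 heavy atoms and are weaker than compound 1 with its larger group, so group size alone does not set the order. No available evidence explains the effect of this rearrangement.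

Going by these compounds, it remains open whether adding a methyl group or a fluorine atom to the group in compound 4 would preserve this result. Whether another arrangement of the same atoms would do better is also unknown.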